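Clearance notes on the acrylamide series

The source may report more compounds than this note shows. Statements on the series, on what has been measured and on what is new or still open speak of the compounds shown alone.

Of the compounds shown here, three on a shared core have been read in an ADME assay on the whole organism (strain Sprague-Dawley) for pharmacokinetics, with Rattus norvegicus as the target, read by LC-MS, at a dose of 25 mg/kg by the oral route; a higher number here means faster removal of the compound, a lower number slower removal. Compound 1 `C=CC(=O)N1CC[C@H](N2C(=O)N(c3ccccc3)Cc3cnc(Nc4cccc(N5CCN(C)CC5)c4)nc32)C1` gives 565 mL/min/kg; compound 2 `C=CC(=O)N1CC[C@H](N2C(=O)N(c3ccccc3)Cc3cnc(Nc4ccc(N5CCN(C)CC5)c(OC)c4)nc32)C1` gives 467 mL/min/kg; compound 3 `C=CC(=O)N1CC[C@H](N2C(=O)N(c3ccccc3)Cc3cnc(Nc4ccc(C5CCN(C)CC5)cc4)nc32)C1` gives 335 mL/min/kg. Compound 2 stands second highest of the three, yet its gaps to compound 1 and to compound 3 both lie within the scatter, so no order among them is claimed. Compound 4 `C=CC(=O)N1CC[C@H](N2C(=O)N(c3ccccc3)Cc3cnc(Nc4ccc(N5CCN(C)CC5)c(C)c4)nc32)C1` is not yet measured in this assay. For the measured compounds named here, it differs from compound 2 as follows: methyl in place of methoxy on an aromatic carbon No step between measured compounds isolates such a change, so the expectation rests on compound 2 with its 467 mL/min/kg. The step of a 1.0-fold lower number from compound 2 to compound 4 (0.02 log units; within the scatter) is expected to stay within the scatter, with no clear direction. Compound 4 is estimated at 450 mL/min/kg, in the range 230 mL/min/kg to 850 mL/min/kg.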

Compound 4, clearance: 167 mL/min/kg
Beside the measured number, compound 4's estimate is 2.7-fold (0.43 log units) above it; the whole stated range lies above it.
By their numbers in this assay, from the lowest: compounds 4, 3, 2 and 1 (each within the scatter of the next, the first and the last beyond it).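

In this assay, the aromatic carbon ortho to the 4-methylpiperazin-1-yl group proves sensitive to a small change: methyl in place of methoxy gives a 2.8-fold lower number from compound 2 to compound 4 (0.45 log units; beyond the scatter). For the compounds shown here, this is the only single-place step so far, and it lies beyond the scatter. No measurement at hand accounts for it.

As far as these compounds go, whether an ethyl group, a fluorine or an amine on this carbon would read like methyl or like methoxy stays open. This single pair also leaves open whether the step carries over to the side chains of compound 1 or compound 3.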